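Chloro on the benzoyl ring of the tetrahydroquinoline amides

The source may hold more compounds than are shown below. What is called first, only, known or untested is meant among the compounds shown, and "the series" means these compounds.

Measured so far:
- compound 1, `O=C(Nc1ccccc1C(F)(F)F)C1CCc2ccccc2N1C(=O)c1ccccc1`: 6340 nM
- compound 2, `O=C(Nc1ccccc1C(F)(F)F)C1CCc2ccccc2N1C(=O)c1ccc(Cl)cc1`: 307 nM
- compound 3, `O=C(Nc1cc(C(F)(F)F)cc(C(F)(F)F)c1)C1CCc2ccccc2N1C(=O)c1ccccc1`: 2130 nM

All three have been run in a functional assay on NCI-H23 cells (Homo sapiens) for cytotoxicity, read by sulforhodamine B assay, with a stated time of 72 h; a higher number here means a weaker inhibitor of growth, a lower number a stronger inhibitor of growth. Compound 1 and compound 2 share a core and differ by chloro in place of hydrogen on an aromatic carbon; that step gives a 21-fold lower number from compound 1 to compound 2 (1.31 log units; beyond the scatter). Compound 3 carries a different anilide part; the difference between its core and that of compound 1 is not broken down here. In this assay compound 3 sits between the two, with a higher number than compound 2 and a lower number than compound 1.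

Compound 4, `O=C(Nc1cc(C(F)(F)F)cc(C(F)(F)F)c1)C1CCc2ccccc2N1C(=O)c1cccc(Cl)c1`, has not yet been measured. It differs from compound 3 by chloro in place of hydrogen on an aromatic carbon. This is the same kind of change as from compound 1 to compound 2, but not the same: in compound 2 the chloro sits para to a large group, in compound 4 it sits meta to a large group. Going by the values given here, the only precedent for adding chloro to the benzoyl ring is the step of a 21-fold lower number from compound 1 to compound 2 (1.31 log units; beyond the scatter), a large one. Because the precedent step a 21-fold lower number from compound 1 to compound 2 (1.31 log units; beyond the scatter) comes with chloro para to a large group while compound 4 carries it meta to a large group, the expected step of a 4.7-fold lower number from compound 3 to compound 4 (0.68 log units; beyond the scatter) is taken as smaller than that precedent, and the expectation rests on one pair only. Compound 4 is expected to give about 450 nM in this assay, with a range from 130 nM to 1600 nM.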

Compound 4, concentration for 50% growth inhibition: 420 nM
Estimate against measurement, compound 4: 1.1-fold (0.03 log units) above; the measured number falls inside the stated range.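

In this assay, chloro in place of hydrogen on the benzoyl ring lowers the number on both cores, and the new step, a 5.1-fold lower number from compound 3 to compound 4 (0.71 log units; beyond the scatter), keeps the direction of the earlier one but not its size: the same change on two cores in this assay, a 21-fold lower number (1.31 log units; beyond the scatter) from compound 1 to compound 2 and a 5.1-fold lower number (0.71 log units; beyond the scatter) from compound 3 to compound 4, 4.1-fold (0.61 log units) apart, beyond the scatter of two such steps

The two pairs differ in two respects at once: the anilide part changes from one core to the other, and the chloro in compound 4 is meta to a large group, whereas in compound 2 it stands at another place on the ring. These data therefore cannot assign the gap to either difference. Two pairs support the direction of the change only on these two cores, and they give no rule for how large the step will be on any other core.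

The compounds shown leave open how much of the gap follows the place of the chloro and how much follows the anilide part, a question that would need the same chloro placement on both cores. They also leave open whether the step is specific to chloro or is shared by other groups at the same place on the benzoyl ring, such as fluoro, methoxy, a nitrile or a carboxylic acid.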